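Chloro in place of bromo on the aromatic ring of compound 1

The source may hold more compounds than are shown below. What is called first, only, known or untested is meant among the compounds shown, and "the series" means these compounds.

Measured compounds:
compound 1 `CCN1CCc2c(c(C)nn2C(=O)Nc2ccc(Br)cc2)C1`: 81.6%
compound 2 `CCN1CCc2c(c(C)nn2C(=O)Nc2ccc(F)cc2F)C1`: 14.3%

In a functional assay on the whole organism (strain Swiss albino) for inhibition, with Mus musculus as the target, in the formalin test, with a stated time of 30 min, at a dose of 100 mg/kg (on this read-out higher numbers stand for more inhibition at the one dose given (going by the name of the read-out) and lower numbers for less inhibition), compound 1 gives 81.6%, the highest of the two numbers; compound 2 gives 14.3%, a gap beyond the scatter. Among the compounds with values here, compound 1 and compound 2 differ in more than one place on the six-membered aromatic ring of carbon only, so no single step can be read between them; the two values show only that compound 1 sits well above compound 2 in this assay.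

Compound 3 `CCN1CCc2c(c(C)nn2C(=O)Nc2ccc(Cl)cc2)C1` has not been measured. It differs from compound 1 by chloro in place of bromo on an aromatic carbon. Bromine and chlorine are the closest pair among the halogens, and nothing measured here separates them, so the step from compound 1 to compound 3 is expected to be small, on the order of the scatter, with at most a slight fall, expressed as a number 7.6 percentage points lower from compound 1 to compound 3 (within the scatter). Compound 3 is therefore expected to give 74% in this assay, within a range of 55% to 90%.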

Compound 3, a percentage reported as inhibition, in the whole organism at one dose (the size of the read-out at that dose, not a potency): 7.5%
The estimate for compound 3 lay 66.5 percentage points above the measured number, outside the stated range (below it).
By their numbers in this assay, from the lowest: compounds 3 and 2 (each within the scatter of the next); then compound 1.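

Chloro in place of bromo on an aromatic carbon, para to a large group, gives in this assay a number 74.1 percentage points lower from compound 1 to compound 3 (beyond the scatter), the first step in the series that can be read at a single place. It shows that this position does not treat the two halogens alike: the exchange of one heavy atom for another, with no change in the counted donors, acceptors or charge, is enough to take away most of the inhibition seen with bromo. A halogen at this place is therefore not sufficient in itself, and the high number belongs to the 4-bromophenyl compound rather than to 4-halophenyl compounds in general, although nothing measured here bears on the reason for the step.

The compounds shown leave open how iodo, methyl, methoxy or an amine would read at this same position, and so whether bromo is a narrow optimum or one point on a broader trend. They also leave open whether the step survives with a benzyl group in place of the ethyl group on the core, and whether it would hold at doses other than the one given.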